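Aminophenyl for methylphenyl in a nitroimidazooxazole alkyne

This account rests on a few compounds, and the source may have more. Where it says the series, first, only, none or still open, it means among the compounds named here.

Measured so far:
- compound 1 `Cc1ccc(C#Cc2c([N+](=O)[O-])nc3n2CC(C)O3)cc1`: 4440 nM
- compound 2 `CC1Cn2c(nc([N+](=O)[O-])c2C#Cc2ccc(CO)cc2)O1`: 9000 nM

In an ADME assay on HepG2 cells (Homo sapiens) for cytotoxicity, read by MTT assay, with a stated time of 24 h (on this read-out higher numbers stand for lower toxicity in this test and lower numbers for higher toxicity in this test), compound 1 gives the lowest of the two numbers, the nearest being compound 2 with 9000 nM, reached by a 2.0-fold higher number from compound 1 to compound 2 (0.31 log units; beyond the scatter). Compound 3 `CC1Cn2c(nc([N+](=O)[O-])c2C#Cc2cccc(N)c2)O1` differs from compound 1 by 3-aminophenyl in place of 4-methylphenyl on a triple-bonded carbon. No measured step changes the ring in this way; the only step shown, from compound 1 to compound 2, also brings in a hydrogen-bond donor and acceptor, and that step was modest. Compound 3 is therefore expected to lie close to compound 1, with a 1.4-fold higher number from compound 1 to compound 3 (0.13 log units; within the scatter), estimated at 6000 nM within 2500 nM to 15000 nM.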

Compound 3, half-maximal cytotoxic concentration: 8300 nM
For compound 3 the middle estimate is 1.4-fold (0.14 log units) below the measured one; the measured number falls inside the stated range.
By their numbers in this assay, from the lowest: compounds 1, 3 and 2 (each within the scatter of the next, the first and the last beyond it).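

In this assay, 3-aminophenyl in place of 4-methylphenyl on a triple-bonded carbon gives a 1.9-fold higher number from compound 1 to compound 3 (0.27 log units; within the scatter). This position therefore accepts an amino-bearing ring, which adds a hydrogen-bond donor and acceptor, without a step beyond the scatter. The step changes both the group and its place on the ring, so their separate contributions cannot be told apart.

As far as these compounds go, how an unsubstituted phenyl ring or a carboxylic acid on the ring would read here remains open. Nothing available explains this result.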